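The compounds below may be only part of what the source reports. "The series", "measured", "known", "first", "only" and "open" are said of these compounds alone.

Compound 1 `COc1ncc(-c2ccc3nc(NC(=O)NCCN4CCCC4)sc3c2)cc1NS(=O)(=O)c1ccc(F)cc1` gives 300 nM in a functional assay on A549 cells (Homo sapiens) for antiproliferative activity, read by MTT assay, with a stated time of 72 h; on this read-out lower numbers stand for stronger inhibition and higher numbers for weaker inhibition.
Compound 2 `CCN(CC)CCNC(=O)Nc1nc2ccc(-c3cnc(OC)c(NS(=O)(=O)c4ccc(F)cc4)c3)cc2s1` gives 450 nM in this assay.

Compound 1 holds the smaller of the two numbers, yet a 1.5-fold higher number from compound 1 to compound 2 (0.18 log units; within the scatter) shows compound 2 indistinguishable from it. Compound 3 `COc1ncc(-c2ccc3nc(NC(=O)NCCN4CCCCC4)sc3c2)cc1NS(=O)(=O)c1ccc(F)cc1` differs from compound 1 by piperidin-1-yl in place of pyrrolidin-1-yl on a saturated chain carbon, two bonds along the chain from an amide-type nitrogen. For the measured compounds named here, the one measured step at this place, a 1.5-fold higher number from compound 1 to compound 2 (0.18 log units; within the scatter), swapped a ring amine for an open-chain amine without moving the number beyond scatter. Compound 3 is therefore expected to stay close to compound 1, with no step beyond the scatter. The estimate for compound 3 is 350 nM, range 150 nM to 800 nM. This expected step is a 1.2-fold higher number from compound 1 to compound 3 (0.07 log units; within the scatter).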

Compound 3, half-maximal inhibitory concentration: 330 nM
For compound 3 the middle estimate is 1.1-fold (0.03 log units) above the measured one, within the range that was stated.
By their numbers in this assay, from the lowest: compounds 1, 3 and 2 (each within the scatter of the next).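

In this assay ring size at this place now has its own reading, with a 1.1-fold higher number from compound 1 to compound 3 (0.04 log units; within the scatter) for piperidin-1-yl in place of pyrrolidin-1-yl and a 1.4-fold lower number from compound 2 to compound 3 (0.13 log units; within the scatter) for piperidin-1-yl in place of diethylamino on the same chain. A five-membered ring, a six-membered ring and an open-chain amine therefore all lie within the scatter of one another here. Nothing available explains this tolerance. As far as these compounds go, whether morpholin-4-yl, a primary amine or a carboxylic acid at this place would leave the number equally unmoved stays open, as does the effect of a longer chain.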